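Swapping an acetoxy ester for a diol on the urea nitrogen

A few compounds are considered here, and "the series" means these few. Any claim that something is new, unique, unknown or untested is made for them only; others in the source may bear on it.

Compound 3 `CC(=O)OCC(C)(C)NC(=O)N(CCC1CCN(Cc2ccc(C)cc2)CC1)Cc1ccc(-c2ccccc2)cc1` is one of three close relatives tested in an in vitro functional assay on HEK293 cells for antagonist activity at melanin-concentrating hormone receptor 1 (Homo sapiens), read by GTPgammaS binding, with a stated time of 45 min (on this read-out lower numbers stand for stronger inhibition and higher numbers for weaker inhibition), where compound 3 gives 366 nM. Compound 1 `CC(=O)OCC(C)(C)NC(=O)N(CCC1CCN(Cc2ccc(C)cc2)CC1)Cc1ccc(-c2ccc(F)cc2)cc1` gives 409 nM, and compound 2 `COc1ccc(-c2ccc(CN(CCC3CCN(Cc4ccc(C)cc4)CC3)C(=O)NC(C)(C)COC(C)=O)cc2)cc1` gives 647 nM; the steps of a 1.1-fold lower number from compound 1 to compound 3 (0.05 log units; within the scatter) and a 1.8-fold lower number from compound 2 to compound 3 (0.25 log units; within the scatter) leave compound 3 indistinguishable from its relatives. Compound 4 `CCC(CO)(CO)NC(=O)N(CCC1CCN(Cc2ccc(C)cc2)CC1)Cc1ccc(-c2ccccc2)cc1` has not been measured. It differs from compound 3 by 1,1-bis(hydroxymethyl)propyl in place of 1-(acetoxymethyl)-1-methylethyl on an amide-type nitrogen. Within the data shown here, none of the measured steps touches this part of the molecule, since all three concern a single aromatic substituent, so they offer no direct guide. With nothing to suggest a shift, the expected step is a 1.1-fold higher number from compound 3 to compound 4 (0.04 log units; within the scatter), essentially none beyond the scatter. Compound 4 is therefore estimated at 400 nM, with a range from 100 nM to 1600 nM.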

Compound 4, antagonist equilibrium constant: 147 nM
Compound 4: middle estimate off by 2.7-fold (0.43 log units), on the high side, and the stated range covers the measured number.
By their numbers in this assay, from the lowest: compound 4; then compounds 3, 1 and 2 (each within the scatter of the next).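

The group on the amide-type nitrogen matters in a way the aromatic substituent did not, since the earlier aromatic changes all stayed within the scatter. In this assay, replacing 1-(acetoxymethyl)-1-methylethyl with 1,1-bis(hydroxymethyl)propyl gives a 2.5-fold lower number from compound 3 to compound 4 (0.40 log units; beyond the scatter), and this swap removes the ester and adds 2 hydrogen-bond donors in a single change. Nothing available explains why the number falls.

From the compounds shown here alone, whether one hydroxymethyl group would suffice remains open, as does how an amine or a carboxylic acid would behave at this place.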